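The compounds below may be only part of what the source reports. "The series", "measured", "known", "first", "only" and "open" are said of these compounds alone.

Measured compounds in a functional assay on HT-29 cells (Homo sapiens) for antiproliferative activity, read by MTT assay, with a stated time of 48 h; on this read-out higher numbers stand for weaker inhibition of growth and lower numbers for stronger inhibition of growth:
compound 1 `COc1cc(C2CC(c3ccccc3)=NN2C(=O)OCc2ccccc2)cc(OC)c1OC` — > 10000 nM
compound 2 `COc1cc(C2CC(c3cccc(O)c3)=NN2C(=O)OCc2ccccc2)cc(OC)c1OC` — > 10000 nM
compound 3 `COC(=O)N1N=C(c2ccccc2)CC1c1ccc(OC)c(O)c1` — 3500 nM

The value of compound 1 is a limit of this assay, not a number. The value of compound 2 is likewise a limit of this assay. For the measured compounds named here, compound 3 gives the only number in the set, 3500 nM. Compound 1 and compound 2 both sit at the limit described by the limit of > 10000 nM in this assay, at which 2 of the 3 values shown sit. The change hydrogen in place of hydroxy on an aromatic carbon is measured between compound 2 and compound 1, but the step that the two limits leave unreadable from compound 2 to compound 1 cannot be read, since both ends rest on the limit (the limit of > 10000 nM in this assay, at which 2 of the 3 values shown sit). How the core of compound 3 differs from the core of compound 2 is not broken down here.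

Compound 4 `COC(=O)N1N=C(c2ccccc2)CC1c1ccc(OC)cc1` is not yet measured in this assay. It differs from compound 3 by hydrogen in place of hydroxy on an aromatic carbon, the same kind of change as that from compound 2 to compound 1, though here the place is ortho to a methoxy group (2 heavy atoms), which is not so in the earlier pair. Because the step that the two limits leave unreadable from compound 2 to compound 1 is unreadable, no measured size guides the expectation. A loss is expected, the estimated step being a 2.6-fold higher number from compound 3 to compound 4 (0.41 log units; beyond the scatter), with a real chance that only a limit is returned. Compound 4 is therefore expected at about 9000 nM, within 3000 nM to 30000 nM.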

Compound 4, concentration for 50% growth inhibition: > 10000 nM
Compound 4: no number, only a limit; the forecaster's own chance of this, stated with the estimate: 40%; at least 1.1-fold (0.04 log units) between middle value and limit.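

In this assay, hydrogen in place of the hydroxy on the core of compound 3 gives an at least 2.8-fold higher number from compound 3 to compound 4 (0.45 log units; beyond the scatter), a loss of growth inhibition beyond the scatter, and the hydroxy is the only difference between the two compounds. Compound 4 gives > 10000 nM, which is a limit and not a number, and compound 1 and compound 2 rest on the same limit: the limit of > 10000 nM in this assay, at which 3 of the 4 values shown sit.
The same kind of change from compound 2 to compound 1 cannot be read, and there the place is not ortho to a methoxy group, so this step stands alone and shows neither that the change carries from one core to another nor that it does not.

Going by these compounds, what an amine or a carboxylic acid in place of the hydroxy of compound 3 gives in this assay stays open. Also open, on these data alone, is whether a hydroxy ortho to a methoxy group returns a number on the core of compound 1.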